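The source may report more compounds than this note shows. Statements on the series, on what has been measured and on what is new or still open speak of the compounds shown alone.

Measured so far in a functional assay on K562 cells (Homo sapiens) for antiproliferative activity, read by MTT assay, with a stated time of 72 h; on this read-out higher numbers stand for weaker inhibition and lower numbers for stronger inhibition:
Compound 1 `O=C1NC(=S)S/C1=C\C1=Cc2ccccc2OC1`, for which compound 1 gives 55300 nM.
Compound 2 `O=C1NC(=O)/C(=C/C2=Cc3ccccc3OC2)N1`, for which compound 2 gives 55700 nM.
Compound 3 `O=C1NC(=S)S/C1=C\C1=Cc2cc(Br)ccc2OC1`, for which compound 3 gives 33700 nM.

Compound 1 and compound 2 carry different cores; the difference between the two cores is not broken down here. Their two numbers lie within the scatter of each other, so nothing can be said of an order between them. Compound 3 is compound 1 with bromo in place of hydrogen on an aromatic carbon, and this change made a 1.6-fold lower number from compound 1 to compound 3 (0.22 log units; within the scatter).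

Compound 4 `O=C1NC(=O)/C(=C/C2=Cc3cc(Br)ccc3OC2)N1` has not yet been measured in this assay. It stands to compound 2 as compound 3 stands to compound 1, with bromo in place of hydrogen on an aromatic carbon; the place of the change is described in the same words in both pairs, so it is the same change, seen twice among these compounds. The expectation for compound 2 to compound 4 rests on that single earlier step, because a 1.6-fold lower number from compound 1 to compound 3 (0.22 log units; within the scatter) was small and within the scatter. The change is expected to make a 1.5-fold lower number from compound 2 to compound 4 (0.17 log units; within the scatter). Compound 4 is therefore estimated at 38000 nM, with a likely range from 18000 nM to 80000 nM.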

Compound 4, half-maximal inhibitory concentration: 79300 nM
Beside the measured number, compound 4's estimate is 2.1-fold (0.32 log units) below it; the measured number falls inside the stated range.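

In this assay, bromo in place of hydrogen on an aromatic carbon gives a 1.4-fold higher number from compound 2 to compound 4 (0.15 log units; within the scatter), so on this core the change stays within the scatter. Set beside the earlier step, the two readings cannot be told apart: the same change on two cores in this assay, a 1.6-fold lower number (0.22 log units; within the scatter) from compound 1 to compound 3 and a 1.4-fold higher number (0.15 log units; within the scatter) from compound 2 to compound 4, 2.3-fold (0.37 log units) apart, within the scatter of two such steps. This shows that the change moved the number by no more than the scatter on either of the two cores, and nothing here suggests that the core alters its outcome, but it does not show that the change carries over with a shared direction or size, and two steps this small cannot establish that it has no effect at all.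

The compounds shown carry only hydrogen or bromo at this place, so it remains open whether a larger departure, such as an amine, a methoxy group or a carboxylic acid there, would move the number beyond the scatter on either core. From the compounds shown here alone, whether such a group would behave alike on the two cores also remains open.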